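Phenyl for Isopropyl on the Aromatic Nitrogen

The source may hold more compounds than are shown below. What is called first, only, known or untested is meant among the compounds shown, and "the series" means these compounds.

Compound 1, `Cc1nn(C)c2c1C(c1cccc(Cl)c1)=NCC(=O)N2`: > 500 mg/kg
Compound 2, `CCc1nn(C)c2c1C(c1cccc(F)c1)=NCC(=O)N2C`: 32 mg/kg
Compound 3, `Cc1nn(C(C)C)c2c1C(c1ccccc1Cl)=NCC(=O)N2`: 16 mg/kg

Of the compounds shown here, three sharing one core have been tested in a functional assay on the whole organism with Rattus norvegicus as the target; on this read-out lower numbers stand for an effect already at smaller amounts and higher numbers for an effect only at larger amounts of compound. Compound 3 gives 16 mg/kg, the lowest of the two numbers measured. Compound 2 gives 32 mg/kg, a figure that lies within the usual scatter of the reading for compound 3, so the two cannot be ranked. For compound 1 the assay returned only a limit, (the limit of > 500 mg/kg in this assay, at which 1 of the 3 values shown sits), and no number. Within the data shown here, no two of the measured compounds differ in a single place, so no measured step is available.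

Compound 4, `Cc1nn(-c2ccccc2)c2c1C(c1ccccc1Cl)=NCC(=O)N2`, is the next compound to be tested. It differs from compound 3 in one respect: phenyl in place of isopropyl on an aromatic nitrogen. Among the measured compounds shown here, with no comparable step among the measured compounds, the size of the change is open; a step within the scatter, in either direction, is the most that can be expected. Compound 4 is therefore expected to give about 25 mg/kg in this assay, in a range from 8 mg/kg to 100 mg/kg. The step of a 1.6-fold higher number from compound 3 to compound 4 (0.19 log units; within the scatter) that this estimate means is expected to stay within the scatter.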

Compound 4, minimum effective dose: 500 mg/kg
The estimate for compound 4 lay 20-fold (1.30 log units) below the measured number; the whole stated range lies below it.
By their numbers in this assay, from the lowest: compounds 3 and 2 (each within the scatter of the next); then compound 4.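

Among these compounds, on the aromatic nitrogen the choice of group matters strongly: in this assay, phenyl in place of isopropyl gives a 31-fold higher number from compound 3 to compound 4 (1.49 log units; beyond the scatter), the first step that changes a single place. Both groups are all carbon, with no hydrogen-bond donors or acceptors and no net charge, yet the step is large. Compound 1 gave only a limit, and the number for compound 4 stands at that same figure: the limit of > 500 mg/kg in this assay, at which 1 of the 4 values shown sits.

The compounds shown leave open whether the step goes with the aromatic ring itself or with the greater count of carbon, a question that a cyclohexyl group on this nitrogen would address. They also leave open how a chain ending in an amine or a carboxylic acid would read at this position.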